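Aryloxyacetamide series: nitrogen substituent swap, compound 1 to compound 3

This account rests on a few compounds, and the source may have more. Where it says the series, first, only, none or still open, it means among the compounds named here.

Two compounds of the shared core have numbers in an assay on HEK293 cells for agonist activity at transient receptor potential cation channel subfamily M member 8 (Homo sapiens), read by fluorescence and calcium flux, with a stated time of 15 min; a higher number here means that more compound is needed for the effect, a lower number that less compound is needed. Compound 1 `Cc1ccc(OCC(=O)N(Cc2cccs2)c2ccn(C)n2)cc1` gives 855 nM, and compound 2 `CCN(Cc1ccccc1)C(=O)COc1ccc(C)cc1` gives 1880 nM. Compound 1 therefore stands at the lower of the two numbers, and its gap to compound 2 lies beyond the scatter. Compound 2 is the only other measured point, and it differs from compound 1 in more than one place, so nothing can be read from the pair beyond the two values themselves.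

Compound 3 `Cc1ccc(OCC(=O)N(CCO)Cc2cccs2)cc1` is still to be measured in this assay. It departs from compound 1 by 2-hydroxyethyl in place of 1-methyl-1H-pyrazol-3-yl on an amide-type nitrogen. Within the data shown here, no measured pair isolates this change, so the expected size of the step rests on general experience with this kind of replacement. Compound 3 is expected to need more compound than compound 1, a step of a 2.9-fold higher number from compound 1 to compound 3 (0.47 log units; beyond the scatter), going beyond the scatter in the direction of a higher number. For compound 3 the estimate in this assay is 2500 nM, with a likely range from 900 nM to 7000 nM.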

Compound 3, half-maximal effective concentration: 900 nM
The estimate for compound 3 lay 2.8-fold (0.44 log units) above the measured number; the range from low to high includes it.
By their numbers in this assay, from the lowest: compounds 1 and 3 (each within the scatter of the next); then compound 2.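

Among these compounds, replacing 1-methyl-1H-pyrazol-3-yl with 2-hydroxyethyl on the amide-type nitrogen gives the first single-place comparison in this assay: a 1.1-fold higher number from compound 1 to compound 3 (0.02 log units; within the scatter). At this position, therefore, a five-membered aromatic ring with 2 hetero atoms and 6 heavy atoms can give way to a ringless group of 3 heavy atoms, with 1 hydrogen-bond donor where there were 0, without a change in the number beyond the scatter, so for this pair the aromatic ring is not needed to hold the value. Nothing available bears on why these two different groups read alike in this assay.

Open at this nitrogen is whether the result extends to a longer hydroxyalkyl chain, or to the methyl ether of the same chain, which would show whether the hydroxyl hydrogen plays any part in the number. Also open, from the compounds shown here alone, is whether a terminal amine or a carboxylic acid on the chain would stay within the scatter of compound 1, since one pair cannot show how far this position tolerates change.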